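The source may report more compounds than this note shows. Statements on the series, on what has been measured and on what is new or still open speak of the compounds shown alone.

Of the compounds shown here, three built on the same core have so far been measured in an ADME assay on microsomes from liver (Homo sapiens) for pharmacokinetics, read by LC-MS, with a stated time of 60 min, tested at 1 uM; a lower number here means slower removal, a higher number faster removal of the compound. Compound 1 `O=C(NCc1ccc(S(=O)(=O)c2cc(F)cc(F)c2)cc1)N1Cc2ccncc2C1` gives 8 mL/min/kg, which stands as the highest of the three numbers, although both other compounds sit within the scatter of it. Compound 2 `O=C(NCc1ccc(S(=O)(=O)C2CCOCC2)cc1)N1Cc2ccncc2C1` gives 6 mL/min/kg in this assay, and compound 3 `O=C(NCc1ccc(S(=O)(=O)N2CCC(O)CC2)cc1)N1Cc2ccncc2C1` gives 6 mL/min/kg. The step of a 1.3-fold lower number from compound 1 to compound 2 (0.12 log units; within the scatter) and the step of a 1.3-fold lower number from compound 1 to compound 3 (0.12 log units; within the scatter) are alike in size and direction, and the step of no change at the digits printed from compound 2 to compound 3 (within the scatter) shows that the two replacements on the sulfonyl sulfur land on the same number.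

Compound 4 `CN1CCN(S(=O)(=O)c2ccc(CNC(=O)N3Cc4ccncc4C3)cc2)CC1` has not yet been measured in this assay. It differs from compound 1 in one place: 4-methylpiperazin-1-yl in place of 3,5-difluorophenyl on a sulfonyl sulfur. The measured steps that bear on this change are the two that likewise exchange the group on the sulfonyl sulfur of compound 1, namely a 1.3-fold lower number from compound 1 to compound 2 (0.12 log units; within the scatter) and a 1.3-fold lower number from compound 1 to compound 3 (0.12 log units; within the scatter); neither moved beyond the scatter, and both leaned toward a lower number. Compound 4 is therefore expected to show no step beyond the scatter in this assay, with at most a slight lean downward, as in a 1.3-fold lower number from compound 1 to compound 4 (0.12 log units; within the scatter). Compound 4 is estimated at 6 mL/min/kg in this assay, with a range from 3 mL/min/kg to 12 mL/min/kg.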

Compound 4, clearance: 9 mL/min/kg
Compound 4: middle estimate off by 1.5-fold (0.18 log units), on the low side; the measured number falls inside the stated range.
By their numbers in this assay, from the lowest: compounds 2, 3, 1 and 4 (each within the scatter of the next).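

With 4-methylpiperazin-1-yl on the sulfonyl sulfur, the exchange for 3,5-difluorophenyl gives a 1.1-fold higher number from compound 1 to compound 4 (0.05 log units; within the scatter) in this assay, so a third replacement at this position also stays within the scatter, and the steps from compound 1 no longer all point the same way. The same holds against the two other replacements, with a 1.5-fold higher number from compound 3 to compound 4 (0.18 log units; within the scatter) and a 1.5-fold higher number from compound 2 to compound 4 (0.18 log units; within the scatter), so the shared direction of the two earlier steps from compound 1 cannot be read as a trend. Across these four compounds, 3,5-difluorophenyl, oxan-4-yl, 4-hydroxypiperidin-1-yl and 4-methylpiperazin-1-yl on this sulfur all remain within the scatter of one another, which the three earlier compounds could show only for the first three groups.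

Nothing available here explains why these groups give such similar numbers. Going by these compounds, it remains open whether a group of another kind on the sulfonyl sulfur, such as a carboxylic acid or a primary amine at the end of a longer chain, would produce a step beyond the scatter, and whether changes elsewhere on the shared core would do so.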